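The source may report more compounds than this note shows. Statements on the series, on what has been measured and on what is new or still open speak of the compounds shown alone.

Working notes on the series. The shared core of the three measured compounds carries an aryloxy side chain ending in an amine, and all three have been read in a functional assay on the whole organism (heart) with Rattus norvegicus as the target; a lower number here means that less compound is needed, a higher number that more compound is needed for the effect. Compound 1 `CC(=O)/C(=C\c1ccccc1)Oc1ccc(OCC(C)N(C)C)cc1` gives 3 mg/kg and stands as the highest number of the three. Compound 2 `CC(=O)/C(=C\c1ccccc1)Oc1ccccc1OCCCN(C(C)C)C(C)C` gives 0.1 mg/kg, and compound 3 `CC(=O)/C(=C\c1ccccc1)Oc1ccccc1OCCCN(C)C` gives 0.37 mg/kg; compound 1 thus sits well above both, its gap to compound 3 and to compound 2 each lying beyond the scatter.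

Compound 4 `CC(=O)/C(=C\c1ccccc1)Oc1ccc(OCC(O)NC(C)(C)C)cc1` has not yet been measured in this assay. Relative to compound 1 the change is hydroxy((tert-butyl)amino)methyl in place of 1-(dimethylamino)ethyl on a saturated chain carbon bound to an oxygen on an aromatic ring.

Among the measured compounds shown here, the only measured step that touches this change is a 3.7-fold higher number from compound 2 to compound 3 (0.57 log units; beyond the scatter), where the smaller amine went with the higher number; it sits on the core of compounds 2 and 3, not on that of compound 1, and it does not cover the hydroxy group that enters with compound 4. On that step alone, the tert-butyl amine of compound 4 is expected to pull the number of compound 1 downward by a modest step, a 2.0-fold lower number from compound 1 to compound 4 (0.30 log units; within the scatter), with wide uncertainty. Compound 4 is therefore estimated at 1.5 mg/kg, in a range of 0.3 mg/kg to 7 mg/kg.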

Compound 4, dose for half-maximal effect: 3.5 mg/kg
Compound 4: middle estimate off by 2.3-fold (0.37 log units), on the low side, within the range that was stated.
By their numbers in this assay, from the lowest: compound 2; then compound 3; then compounds 1 and 4 (each within the scatter of the next).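

In this assay the exchange of 1-(dimethylamino)ethyl for hydroxy((tert-butyl)amino)methyl, on a saturated chain carbon bound to an oxygen on an aromatic ring, gives a 1.2-fold higher number from compound 1 to compound 4 (0.07 log units; within the scatter), so on the core of compound 1 this place accepts the larger group, with its added oxygen and hydrogen-bond donors, without a readable change in the number. The amine exchange on the other core, a 3.7-fold higher number from compound 2 to compound 3 (0.57 log units; beyond the scatter), lies beyond the scatter, and the size of that step does not reappear in this combined change, which alters more than the amine. No measurement shown here bears on why the number holds still at this position.

The compounds shown leave open what the hydroxy group and the tert-butyl amine each contribute alone, as they enter together in compound 4, and a tert-butyl amine on the plain chain without the hydroxy group would separate the two. Also open, from the compounds shown here alone, is how a diisopropylamino group, seen here only on the core of compound 2, reads on the core of compound 1.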